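This account rests on a few compounds, and the source may have more. Where it says the series, first, only, none or still open, it means among the compounds named here.

Compound 1 `CS/C(=N\C(=O)c1ccco1)NC(=O)c1ccco1`: in a functional assay on MCF7 cells (Homo sapiens) for cytotoxicity, read by MTT assay, with a stated time of 72 h (a higher number here means a weaker inhibitor of growth, a lower number a stronger inhibitor of growth), compound 1 gives > 100000 nM, which is a limit of the assay and not a number.
Compound 2 `O=C(/N=C(/NC(=O)c1ccco1)[Se]Cc1ccccc1)c1ccco1`: in this assay compound 2 gives 58000 nM.
Compound 3 `CS/C(=N\C(=O)c1cnc2ccccc2c1)NC(=O)c1cnc2ccccc2c1`: in this assay compound 3 gives > 100000 nM, again a limit of the assay and not a number.

Compounds 1 and 2 share one core and differ in a single place. The change is a group of 8 heavy atoms (7 carbon, 1 selenium; one six-membered aromatic ring of carbon only) in place of a group of 2 heavy atoms (1 carbon, 1 sulfur; no ring), on a carbon with a double bond to nitrogen. In this assay this gave an at least 1.7-fold lower number from compound 1 to compound 2 (0.23 log units; that floor lies within the scatter). The size of that step can only be read as a floor, because of the limit of > 100000 nM in this assay, at which 2 of the 3 values shown sit.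

Compound 3 carries a different core, and the difference between the core of compound 1 and the core of compound 3 is not broken down here. The unmeasured compound 4 `O=C(/N=C(/NC(=O)c1cnc2ccccc2c1)[Se]Cc1ccccc1)c1cnc2ccccc2c1` stands to compound 3 exactly as compound 2 stands to compound 1: the change is a group of 8 heavy atoms (7 carbon, 1 selenium; one six-membered aromatic ring of carbon only) in place of a group of 2 heavy atoms (1 carbon, 1 sulfur; no ring), on a carbon with a double bond to nitrogen, at the same place in both pairs, so it is the same change on the new core.

For the measured compounds named here, only one measured example of this change exists, and it begins from a limit, so the step it produced is itself known only as a floor. On that basis compound 4 is expected to move from compound 3 by about an at least 1.6-fold lower number from compound 3 to compound 4 (0.22 log units; that floor lies within the scatter), in line with the step seen from compound 1 to compound 2. The estimate for compound 4 in this assay is 60000 nM, with a range from 20000 nM to 150000 nM.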

Compound 4, concentration for total growth inhibition: > 100000 nM
Compound 4: no number, only a limit; the forecaster's own chance of this, stated with the estimate: 40%; at least 1.6-fold (0.22 log units) between middle value and limit.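

Compound 3 and compound 4 both give a limit of the assay and not a number, so the step from compound 3 to compound 4 cannot be read: the limit of > 100000 nM in this assay, at which 3 of the 4 values shown sit.

The compounds shown leave open whether replacing methylsulfanyl with the selenium-bearing group changes growth inhibition at all on the core of compound 3 in this assay, and by how much.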